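Compound 4: a cyano group replaces the oxime-type group

The source may report more compounds than this note shows. Statements on the series, on what has been measured and on what is new or still open speak of the compounds shown alone.

The three measured compounds share one core and differ only in the group on an aromatic carbon of the fused ring system. In a functional assay on the whole organism (strain Wistar albino) for inhibition, with Rattus norvegicus as the target, read by paw edema, with a stated time of 4 h, at a dose of 100 mg/kg by the oral route (on this read-out lower numbers stand for less inhibition and higher numbers for more inhibition at the one dose given (going by the name of the read-out)), compound 1 `Cc1ccc2c(Cc3nn4c(C=O)c(-c5ccc(Cl)cc5)nc4s3)coc2c1` gives 47.2%. Compound 2 `Cc1ccc2c(Cc3nn4c(CO)c(-c5ccc(Cl)cc5)nc4s3)coc2c1` gives 54.3% in this assay, and the step of a number 7.1 percentage points higher from compound 1 to compound 2 (within the scatter) lies within the scatter. Compound 3 `Cc1ccc2c(Cc3nn4c(/C=N/O)c(-c5ccc(Cl)cc5)nc4s3)coc2c1` gives 11.1%, the lowest of the three numbers, with compound 1 nearest and compound 2 furthest, both beyond the scatter.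

Compound 4 `Cc1ccc2c(Cc3nn4c(C#N)c(-c5ccc(Cl)cc5)nc4s3)coc2c1` has not yet been measured. It differs from compound 3 in one place: a group of 2 heavy atoms (1 carbon, 1 nitrogen; no ring) in place of a group of 3 heavy atoms (1 carbon, 1 nitrogen, 1 oxygen; no ring), on an aromatic carbon.

Going by the values given here, two measured steps bear on this change. The step of a number 36.1 percentage points lower from compound 1 to compound 3 (beyond the scatter) and the step of a number 43.2 percentage points lower from compound 2 to compound 3 (beyond the scatter) both show a large fall when the group of 3 heavy atoms replaced a group of 2 heavy atoms. Among the compounds with values here, compound 4 reverses that direction of change, carrying a group of 2 heavy atoms as compounds 1 and 2 do, though cyano itself has no counterpart among the measured compounds. The account therefore expects compound 4 to recover much of the lost inhibition, with an expected step of a number 28.9 percentage points higher from compound 3 to compound 4 (beyond the scatter). Compound 4 is estimated at 40%, within a range of 18% to 60%.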

Compound 4, a percentage reported as inhibition, in the whole organism at one dose (the size of the read-out at that dose, not a potency): 51.2%
The estimate for compound 4 lay 11.2 percentage points below the measured number, within the range that was stated.
By their numbers in this assay, from the lowest: compound 3; then compounds 1, 4 and 2 (each within the scatter of the next).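

In this assay, the change from the oxime-type group to cyano gives a number 40.1 percentage points higher from compound 3 to compound 4 (beyond the scatter), so the low number of compound 3 does not extend to every nitrogen-bearing group on this aromatic carbon of the five-membered ring. Cyano also falls in with the two groups already measured here, with a number 4 percentage points higher from compound 1 to compound 4 (within the scatter) and a number 3.1 percentage points lower from compound 2 to compound 4 (within the scatter), so formyl, hydroxymethyl and cyano, each of 2 heavy atoms, cannot be told apart at this dose, and compound 3, with its group of 3 heavy atoms, alone stands off from them. No other data here bear on why the group of compound 3 differs from the rest.

The step to compound 4 removes an oxygen and a hydrogen-bond donor and replaces a double bond with a triple bond all at once, so the compounds shown leave open which of these differences goes with the recovered number. They also leave open how a carboxylic acid, an aminomethyl group or a longer alkyl chain at this carbon would read, and whether the three level compounds would stay level at other doses.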